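One chloro fewer on the anilino side of compound 1

The source may report more compounds than this note shows. Statements on the series, on what has been measured and on what is new or still open speak of the compounds shown alone.

Within the data shown here, the series so far holds two measured compounds. Compound 1 `COc1ccc(-c2ccnc(Nc3ccc(Cl)cc3Cl)n2)cc1` gives 23000 nM in a functional assay on HeLa cells (Homo sapiens) for antiproliferative activity, read by MTT assay; a lower number here means a stronger inhibitor, a higher number a weaker inhibitor; compound 2 `COc1cccc(Nc2nccc(-c3ccc(Cl)c(Cl)c3)n2)c1` gives 4970 nM in this assay. Compound 1 thus stands at the highest of the two numbers, and the gap to its nearest neighbour, compound 2, lies beyond the scatter, so compound 2 is the stronger of the two.

Compound 3 `COc1ccc(-c2ccnc(Nc3ccc(Cl)cc3)n2)cc1` has not been measured. It differs from compound 1 by hydrogen in place of chloro on an aromatic carbon. Among the measured compounds shown here, no step between measured compounds isolates this change, so nothing can be carried across directly. The expected step of a 1.3-fold higher number from compound 1 to compound 3 (0.12 log units; within the scatter) is small, toward a slightly higher number, and within the scatter. Compound 3 is therefore expected to give about 30000 nM in this assay, with a range from 10000 nM to 100000 nM.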

Compound 3, half-maximal inhibitory concentration: 310 nM
Beside the measured number, compound 3's estimate is 97-fold (1.99 log units) above it; the whole stated range lies above it.
By their numbers in this assay, from the lowest: compound 3; then compound 2; then compound 1.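

In this assay, replacing the chloro that stands ortho to a large group and meta to a chloro group with hydrogen gives a 74-fold lower number from compound 1 to compound 3 (1.87 log units; beyond the scatter), so this one position strongly controls the read-out in this series. The change removes a single heavy atom and involves no ring, hydrogen-bond donor or acceptor, or net charge, yet the step lies well beyond the scatter. No measurement at hand accounts for the size of this step.

The compounds shown leave open whether a fluoro, methyl or amine group at this position would behave more like hydrogen or more like chloro. Also open is what the remaining chloro contributes, as no compound shown replaces it while the rest of compound 3 stays unchanged.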